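Methoxycarbonyl in place of nitro on compound 3

The source may report more compounds than this note shows. Statements on the series, on what has been measured and on what is new or still open speak of the compounds shown alone.

Compound 1 `CC(C)(O)CCSc1ccc(S(N)(=O)=O)cc1` gives 10
Compound 2 `NS(=O)(=O)c1ccc(SCCCO)c(Cl)c1` gives 9.45
Compound 3 `NS(=O)(=O)c1ccc(S(=O)(=O)CCCO)c([N+](=O)[O-])c1` gives 8

In a physicochemical assay for acid dissociation, compound 3 has the lowest of the three numbers (at 8), and its gaps to compound 2 and compound 1 both lie beyond the usual scatter. Compound 4 `COC(=O)c1cc(S(N)(=O)=O)ccc1S(=O)(=O)CCCO` has not yet been measured. It carries methoxycarbonyl in place of nitro on an aromatic carbon, ortho to a group of 7 heavy atoms and meta to a sulfamoyl group (methoxycarbonyl in place of nitro on an aromatic carbon). Within the data shown here, no two measured compounds differ in only one place, so no measured step shows the size of this change. Compound 3 (at 8) is the closest measured structure and serves as the starting point. A modest upward move in this assay is expected, with an estimated size (a number 0.40 log units higher from compound 3 to compound 4 (beyond the scatter)) near the edge of the usual scatter. The expected value for compound 4 is 8.4 (range 8 to 8.9).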

Compound 4, acid dissociation constant: 8.9
Compound 4: middle estimate off by 0.50 log units, on the low side, and the stated range covers the measured number.
By their numbers in this assay, from the lowest: compound 3; then compound 4; then compound 2; then compound 1.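

In this assay, methoxycarbonyl in place of nitro on an aromatic carbon, ortho to a group of 7 heavy atoms and meta to a sulfamoyl group, gives a number 0.90 log units higher from compound 3 to compound 4 (beyond the scatter). Among these compounds, the earlier compounds differed in more than one place, so this is the only single change whose size can be read, and it lies beyond the scatter. Nothing measured here accounts for that size.

Going by these compounds, whether a nitrile or a carboxylic acid on this aromatic carbon would read closer to nitro or to methoxycarbonyl remains open. So does whether the same change keeps its size on the core of compound 1.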